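Swapping an amide arm for a diol

The compounds below may be only part of what the source reports. "The series", "measured", "known", "first", "only" and "open" are said of these compounds alone.

Measured in a functional assay on LNCaP cells (Homo sapiens) for antiproliferative activity; a higher number here means a weaker inhibitor, a lower number a stronger inhibitor:
- Compound 1 `CNC(=O)C[C@@H]1C[C@@H](c2ccc(Cl)c(Cl)c2)[C@H](NC(=O)c2cc(-c3c(Cl)cnn3C)c(Cl)o2)CN1`: 40 nM
- Compound 2 `Cn1ncc(Cl)c1-c1cc(C(=O)N[C@@H]2CN[C@H](CCNS(C)(=O)=O)C[C@H]2c2ccc(F)c(F)c2)oc1Cl`: 50 nM
- Compound 3 `Cn1ncc(Cl)c1-c1cc(C(=O)N[C@@H]2CN[C@H](CC(O)CO)C[C@H]2c2ccc(F)c(F)c2)oc1Cl`: 100 nM

The values of compound 1 and compound 2 lie within the usual scatter of each other, so these two cannot be told apart here. Compound 3 is a different matter, as its number is higher than that of compound 1 by more than the scatter.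

The next compound to be tested is compound 4 `Cn1ncc(Cl)c1-c1cc(C(=O)N[C@@H]2CN[C@H](CC(O)CO)C[C@H]2c2ccc(Cl)c(Cl)c2)oc1Cl`, which differs from compound 1 in one place: 1,2-dihydroxyethyl in place of methylcarbamoyl on a saturated chain carbon bound to a saturated ring carbon. Put simply, 1,2-dihydroxyethyl stands in place of methylcarbamoyl on a saturated chain carbon bound to a saturated ring carbon.

Among the measured compounds shown here, no measured step removes methylcarbamoyl, so the evidence is indirect. For the measured compounds named here, the one step that bears on the change is a 2.0-fold higher number from compound 2 to compound 3 (0.30 log units; within the scatter). It brings in the same 1,2-dihydroxyethyl, but there it replaces (methanesulfonamido)methyl. Going by the values given here, with only that step as a guide, a small move towards a higher number is expected in this assay, and it may well stay within the scatter.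

The estimated step is a 1.8-fold higher number from compound 1 to compound 4 (0.24 log units; within the scatter). Compound 4 is expected at about 70 nM, with an estimated range from 30 nM to 160 nM.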

Compound 4, half-maximal inhibitory concentration: 70 nM
Beside the measured number, compound 4's estimate shows no gap at the digits printed; measured number inside the range.
By their numbers in this assay, from the lowest: compounds 1, 2, 4 and 3 (each within the scatter of the next, the first and the last beyond it).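

The direct swap on this saturated chain carbon bound to a saturated ring carbon can now be read in this assay: 1,2-dihydroxyethyl in place of methylcarbamoyl gives a 1.8-fold higher number from compound 1 to compound 4 (0.24 log units; within the scatter), so this assay cannot tell the two arms apart when 3,4-dichlorophenyl is on the saturated ring carbon. The same arm can now also be read with a change elsewhere in the molecule, since 3,4-dichlorophenyl in place of 3,4-difluorophenyl gives a 1.4-fold lower number from compound 3 to compound 4 (0.15 log units; within the scatter), and this assay cannot separate those two compounds either. These are two single changes, each small enough to stay within the scatter, but nothing shown gives a measured reason for either result.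

From the compounds shown here alone, it remains open whether a carboxylic acid, a primary amine or a longer chain such as 3,4-dihydroxybutyl at this same place would also stay within the scatter of compound 1. Going by these compounds, it is equally open whether 3,4-dichlorophenyl in place of 3,4-difluorophenyl would give a similar step when the arm is the methanesulfonamido chain of compound 2.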